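Replacing the Methylphenyl Amide in Compound 3

The source may hold more compounds than are shown below. What is called first, only, known or untested is meant among the compounds shown, and "the series" means these compounds.

Measured compounds so far:
- compound 1 `CNC(=O)c1nc(-c2cc(OC)c(OC)c(OC)c2)n(-c2ccc(OC)cc2)n1`: 56%
- compound 2 `COc1ccc(NC(=O)c2nc(-c3cc(OC)c(OC)c(OC)c3)n(-c3ccc(OC)cc3)n2)cc1`: 39%
- compound 3 `COc1ccc(-n2nc(C(=O)Nc3ccccc3C)nc2-c2cc(OC)c(OC)c(OC)c2)cc1`: 19%

All three share the same core and differ only in the group carried on the amide-type nitrogen. In a functional assay on the whole organism for inhibition, with Rattus norvegicus as the target, read by paw edema, with stated times of 30 min and 1 h, at a dose of 0.28 mmol/kg by the oral route (on this read-out lower numbers stand for less inhibition and higher numbers for more inhibition at the one dose given (going by the name of the read-out)), compound 1, with a methyl there, gives 56%; compound 2 gives 39%; compound 3 gives 19%, the lowest of the three numbers, and both of its steps to the others lie beyond the scatter: a number 37 percentage points lower from compound 1 to compound 3 (beyond the scatter) and a number 20 percentage points lower from compound 2 to compound 3 (beyond the scatter).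

Compound 4 `COc1ccc(-n2nc(C(=O)Nc3ccc(O)cc3)nc2-c2cc(OC)c(OC)c(OC)c2)cc1` is the next compound and has not yet been tested. Its difference from compound 3 is 4-hydroxyphenyl in place of 2-methylphenyl on an amide-type nitrogen. The step that bears most directly on this change is a number 20 percentage points lower from compound 2 to compound 3 (beyond the scatter), where a 4-methoxyphenyl on that nitrogen stood higher than the 2-methylphenyl. The 4-hydroxyphenyl of compound 4 resembles compound 2 more than compound 3 in where its substituent sits, so a modest rise in this assay is expected rather than a further fall, though three compounds give a thin basis. Compound 4 is therefore estimated at 35%, in the range 15% to 55%. This expected change corresponds to a number 16 percentage points higher from compound 3 to compound 4 (beyond the scatter).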

Compound 4, a percentage reported as inhibition, in the whole organism at one dose (the size of the read-out at that dose, not a potency): 36%
Compound 4: middle estimate off by 1 percentage points, on the low side, within the range that was stated.
By their numbers in this assay, from the lowest: compound 3; then compounds 4 and 2 (each within the scatter of the next); then compound 1.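

In this assay, the change from 2-methylphenyl to 4-hydroxyphenyl on the amide-type nitrogen gives a number 17 percentage points higher from compound 3 to compound 4 (beyond the scatter) and so shows that this position responds to which substituted phenyl it carries, not only to whether a phenyl is present. Hydrogen in place of methyl on the oxygen gives a number 3 percentage points lower from compound 2 to compound 4 (within the scatter) and so leaves 4-hydroxyphenyl and 4-methoxyphenyl indistinguishable here. The methyl group still stands apart, with a number 20 percentage points lower from compound 1 to compound 4 (beyond the scatter) adding a third phenyl-bearing compound that lies beyond the scatter below compound 1.

Nothing measured here explains these differences. On these data alone, it remains open how this nitrogen would read in this assay with an ethyl or a longer alkyl chain, or with a phenyl carrying an amine or a carboxylic acid.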